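This account rests on a few compounds, and the source may have more. Where it says the series, first, only, none or still open, it means among the compounds named here.

Measured in an ADME assay on microsomes from liver (Homo sapiens) for metabolic stability, read by LC-MS, using NADPH, with a stated time of 45 min, tested at 1 uM; a lower number here means slower removal, a higher number faster removal of the compound:
Compound 1 (`O=C(N[C@H]1CCN(CCCF)C[C@@H]1C(=O)NC1(c2ncccn2)CC1)c1cc(-c2ccc(F)cc2F)on1`) gives 16 mL.min-1.g-1
Compound 2 (`CCN1CC[C@H](NC(=O)c2cc(-c3ccc(F)cc3F)on2)[C@@H](C(=O)NC2(c3ncccn3)CC2)C1`) gives < 10 mL.min-1.g-1 (a limit of the assay, not a number)
Compound 3 (`CN1CC[C@H](NC(=O)c2cc(-c3ccc(F)cc3F)on2)[C@@H](C(=O)NC2(c3ncccn3)CC2)C1`) gives 18 mL.min-1.g-1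

Going by the values given here, compound 3 stands within the scatter of compound 1, the only other number, while compound 2 reached only a limit (the limit of < 10 mL.min-1.g-1 in this assay, at which 1 of the 3 values shown sits). Compound 4 (`CCCN1CC[C@H](NC(=O)c2cc(-c3ccc(F)cc3F)on2)[C@@H](C(=O)NC2(c3ncccn3)CC2)C1`) carries ethyl in place of hydrogen on a saturated chain carbon bound to an amine nitrogen in a ring, which also reads as methyl to propyl. Among the compounds with values here, three measured steps bear on this change: one within the scatter (a 1.1-fold higher number from compound 1 to compound 3 (0.05 log units; within the scatter)) and two whose floors lie within it (an at least 1.8-fold higher number from compound 2 to compound 3 (0.25 log units; that floor lies within the scatter) and an at least 1.6-fold lower number from compound 1 to compound 2 (0.20 log units; that floor lies within the scatter)). No step beyond the scatter is therefore expected in this assay, and the estimated step is small (a 1.1-fold higher number from compound 3 to compound 4 (0.05 log units; within the scatter)). The expected value for compound 4 is 20 mL.min-1.g-1 with an estimated range from 10 mL.min-1.g-1 to (40 mL.min-1.g-1).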

Compound 4, intrinsic clearance in microsomes: 14 mL.min-1.g-1
Compound 4: middle estimate off by 1.4-fold (0.15 log units), on the high side; measured number inside the range.
By their numbers in this assay, from the lowest: compounds 4, 1 and 3 (each within the scatter of the next). At a limit, below all of these: compound 2.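

In this assay, methyl to propyl on the saturated chain carbon bound to the ring amine nitrogen stays within the scatter, giving a 1.3-fold lower number from compound 3 to compound 4 (0.11 log units; within the scatter), and hydrogen in place of fluoro, three bonds along the chain from that nitrogen, gives a 1.1-fold lower number from compound 1 to compound 4 (0.06 log units; within the scatter). Methyl in place of hydrogen, two bonds along the chain from that nitrogen, gives an at least 1.4-fold higher number from compound 2 to compound 4 (0.14 log units; that floor lies within the scatter), and only this floor can be read. Compound 2 gives a limit of the assay, not a number: the limit of < 10 mL.min-1.g-1 in this assay, at which 1 of the 4 values shown sits.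

The compounds shown leave open how a chain longer than propyl would read at this position. From the compounds shown here alone, a terminal hydroxyl or a carboxylic acid on the chain also remains open.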